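The source may hold more compounds than are shown below. What is called first, only, known or untested is meant among the compounds shown, and "the series" means these compounds.

Compound 3 `O=C(CSc1nncnc1-c1cccc2ccccc12)Nc1ccccc1` gives in an ADME assay on MT4 cells (Homo sapiens) for cytotoxicity, read by MTT assay (a lower number here means that less compound is tolerated, a higher number that more compound is tolerated), a value of 154000 nM, the highest of the three numbers in hand. Compound 1 `Cc1ccc(NC(=O)CSc2nncnc2-c2cccc3ccccc23)c([N+](=O)[O-])c1` gives 147000 nM in this assay, which lies within the scatter of compound 3. Compound 2 `O=C(CSc1nncnc1-c1ccccc1Cl)Nc1ccc(Cl)cc1Cl` gives 51000 nM in this assay, a lower number than compound 3 and beyond the scatter; compound 2 differs from compound 3 in more than one place, so its gap is read only for what the two values show.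

Compound 4 `O=C(CSc1nncnc1-c1cccc2ccccc12)Nc1ccccc1Cl` differs from compound 3 by chloro in place of hydrogen on an aromatic carbon. For the measured compounds named here, the one measured step that touches the same ring is a 1.0-fold higher number from compound 1 to compound 3 (0.02 log units; within the scatter), where the whole substituted ring was exchanged for a plain phenyl without a shift beyond the scatter. Compound 2, whose amide-bearing ring carries chloro groups, shows a lower number, but its second difference in the core prevents a clean reading. Adding a single chloro is a smaller change than the step from compound 1 to compound 3, so no shift beyond the scatter is expected, perhaps a slight drift toward a lower number. The estimate for compound 4 in this assay is 120000 nM, expected between 60000 nM and 220000 nM. The expected step is a 1.3-fold lower number from compound 3 to compound 4 (0.11 log units; within the scatter) for compound 4.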

Compound 4, half-maximal cytotoxic concentration: 63000 nM
Beside the measured number, compound 4's estimate is 1.9-fold (0.28 log units) above it; the measured number falls inside the stated range.
By their numbers in this assay, from the lowest: compounds 2 and 4 (each within the scatter of the next); then compounds 1 and 3 (each within the scatter of the next).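

In this assay, for the compounds shown here, the chloro, placed on an aromatic carbon ortho to a large group, gives a 2.4-fold lower number from compound 3 to compound 4 (0.39 log units; beyond the scatter) and is the first change on this ring to move the number beyond the scatter. The earlier exchange on the same ring, a 1.0-fold higher number from compound 1 to compound 3 (0.02 log units; within the scatter), had suggested that the number did not respond to this part of the molecule, but the new compound shows that it can. The other new step, a 2.3-fold lower number from compound 1 to compound 4 (0.37 log units; beyond the scatter), points the same way: 4-methyl-2-nitrophenyl and phenyl give values within the scatter of each other, whereas 2-chlorophenyl stands apart from both, so the presence of a substituent on this ring does not by itself set the number, and no measurement given here explains the shift.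

The compounds shown leave open whether the step belongs to chloro itself or to its place on the ring, since a fluoro or methoxy group in that place, or a 4-chlorophenyl on the same nitrogen, would separate the two. They also leave open whether the same chloro step would appear with a core carrying a different aromatic group.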